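Swapping the sulfonyl aryl group: from nitrile to dichlorophenyl

The source may report more compounds than this note shows. Statements on the series, on what has been measured and on what is new or still open speak of the compounds shown alone.

Compound 1 `O=S(=O)(c1cc(Cl)cc(Cl)c1)c1cnc2c(F)cccc2c1-c1ccc(F)cc1`: 1.01 mL/min
Compound 2 `N#Cc1cccc(S(=O)(=O)c2cnc3c(F)cccc3c2-c2cccc(F)c2)c1`: 0.34 mL/min

In an ADME assay on microsomes from liver (Homo sapiens) for metabolic stability, tested at 2.5 uM (on this read-out lower numbers stand for slow clearance and higher numbers for fast clearance), compound 2 gives the lower of the two numbers, and compound 1 gives 1.01 mL/min against it. Compound 3 `O=S(=O)(c1cc(Cl)cc(Cl)c1)c1cnc2c(F)cccc2c1-c1cccc(F)c1` carries 3,5-dichlorophenyl in place of 3-cyanophenyl on a sulfonyl sulfur. Within the data shown here, no measured pair isolates this change, so the expectation rests on compound 1, whose 3,5-dichlorophenyl sulfonyl group goes with 1.01 mL/min in this assay. A step upward beyond the scatter, a 2.5-fold higher number from compound 2 to compound 3 (0.40 log units; beyond the scatter), is therefore expected. Compound 3 is estimated at 0.85 mL/min in this assay, within 0.45 mL/min to 1.6 mL/min.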

Compound 3, intrinsic clearance in a liver preparation (reported as CLH), per the amount of preparation that the assay uses: 1.08 mL/min
Estimate against measurement, compound 3: 1.3-fold (0.10 log units) below; the range from low to high includes it.
By their numbers in this assay, from the lowest: compound 2; then compounds 1 and 3 (each within the scatter of the next).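

In this assay the sulfonyl aryl change can now be read directly: 3,5-dichlorophenyl in place of 3-cyanophenyl on a sulfonyl sulfur gives a 3.2-fold higher number from compound 2 to compound 3 (0.50 log units; beyond the scatter) and so stands beyond the scatter. By contrast, 3-fluorophenyl in place of 4-fluorophenyl on an aromatic carbon gives a 1.1-fold higher number from compound 1 to compound 3 (0.03 log units; within the scatter) and shows no difference. No measured evidence here accounts for the sulfonyl step.

Among these compounds, only two aryl groups on the sulfonyl sulfur can be compared here, so what a methoxyphenyl or pyridine ring would give there remains open. As far as these compounds go, it is also open whether the step holds with 4-fluorophenyl on the aromatic carbon.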